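A few compounds are considered here, and "the series" means these few. Any claim that something is new, unique, unknown or untested is made for them only; others in the source may bear on it.

Measured in an ADME assay on HCT-116 cells (Homo sapiens) for cytotoxicity, read by CellTiter-Glo, with a stated time of 72 h; on this read-out lower numbers stand for stronger inhibition and higher numbers for weaker inhibition:
Compound 1 `COc1ccc(NC(=O)N2CCC(N3CCC(C)CC3)CC2)cc1`: > 5000 nM (a limit)
Compound 2 `CC1CCN(C2CCN(S(=O)(=O)c3cccc(-c4ccc(F)cc4)c3)CC2)CC1`: > 5000 nM (a limit)
Compound 3 `CC1CCN(C2CCN(S(=O)(=O)c3ccc(-c4ccc(Cl)cc4)cc3)CC2)CC1`: > 5000 nM (a limit)

Compound 3 gives > 5000 nM, which is a limit of the assay and not a number. It has no company of true numbers to be ranked against, and the whole set looks the same: the limit of > 5000 nM in this assay, at which 3 of the 3 values shown sit.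

Compound 4 `CC1CCN(C2CCN(S(=O)(=O)c3ccc(C(C)(C)C)cc3)CC2)CC1` keeps the rest of compound 3 but has tert-butyl in place of 4-chlorophenyl on an aromatic carbon, para to a large group: tert-butyl in place of 4-chlorophenyl on an aromatic carbon.

For the measured compounds named here, no two measured compounds differ in only one place, so the data give no direct size for a change like this. With only limits to go on, no step beyond the usual scatter is expected in this assay, in either direction. The estimated change is a step that the limit leaves unreadable from compound 3 to compound 4. For compound 4 the estimate is 6000 nM, with an expected range from 2500 nM to 15000 nM, and most likely the assay will again report only a limit.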

Compound 4, half-maximal inhibitory concentration: > 5000 nM
Compound 4 ended at the assay's limit (the forecaster's own chance of this, stated with the estimate: 85%); the middle value lies beyond the limit too.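

Compound 3 and compound 4 both give only a limit in this assay, not a number, so no size can be read for tert-butyl in place of 4-chlorophenyl: the limit of > 5000 nM in this assay, at which 4 of the 4 values shown sit.

The compounds shown leave open how strongly any of them acts on these cells, and which change to their structure, if any, would give a true number.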